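The source may report more compounds than this note shows. Statements on the series, on what has been measured and on what is new or still open speak of the compounds shown alone.

Working notes on the series, read in a functional assay on SK-OV-3 cells (Homo sapiens) for antiproliferative activity, read by MTT assay, with a stated time of 72 h; on this read-out higher numbers stand for weaker inhibition and lower numbers for stronger inhibition. Compound 1 `O=C(CCc1cccc2c1B(O)OC2)NCc1ccccc1` gives > 100000 nM, which is a limit of the assay and not a number. Going by the values given here, compound 2 `O=C(CCc1cccc2c1B(O)OC2)Nc1cccc(I)c1` gives 630 nM, the only exact number so far. Compound 3 `O=C(CCc1cccc2c1B(O)OC2)Nc1cccc(-c2ccc(F)cc2)c1` carries 4-fluorophenyl in place of iodo on an aromatic carbon. Among the compounds with values here, the sole measured step, an at least 150-fold lower number from compound 1 to compound 2 (2.20 log units; beyond the scatter), bears only loosely on this change, since it rests on the limit of > 100000 nM in this assay, at which 1 of the 2 values shown sits, and placed 3-iodophenyl in place of benzyl on an amide-type nitrogen. A moderate move to a lower number is expected, with the estimated step being a 2.5-fold lower number from compound 2 to compound 3 (0.40 log units; beyond the scatter). The estimate for compound 3 is 250 nM, with an expected range of 50 nM to 1200 nM.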

Compound 3, half-maximal inhibitory concentration: 93 nM
For compound 3 the middle estimate is 2.7-fold (0.43 log units) above the measured one, and the stated range covers the measured number.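

On an aromatic carbon of a six-membered aromatic ring of carbon only, meta to a large group, 4-fluorophenyl in place of iodo gives a 6.8-fold lower number from compound 2 to compound 3 (0.83 log units; beyond the scatter) and so shows that this position tolerates a group of 7 heavy atoms carrying a further aromatic ring. Going by these compounds alone, this is the first step between two exact numbers, whereas the earlier step rests on a limit: the limit of > 100000 nM in this assay, at which 1 of the 3 values shown sits.

As far as these compounds go, whether the ring or its fluorine carries the step stays open. Also open, from the compounds shown here alone, is what phenyl, morpholine or a carboxylic acid would give on this carbon.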